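The source may report more compounds than this note shows. Statements on the series, on what has been measured and on what is new or still open speak of the compounds shown alone.

Measured compounds:
compound 1, `Cc1cc(Cl)c(S(C)(=O)=O)cc1C(=O)N=C(N)N`, 25 nM
compound 2, `Cc1cc(OC2CCCC2)c(S(C)(=O)=O)cc1C(=O)N=C(N)N`, 27 nM
compound 3, `Cc1cc(OC2CCCCC2)c(S(C)(=O)=O)cc1C(=O)N=C(N)N`, 37 nM

In a functional assay for inhibition of sodium/hydrogen exchanger (Oryctolagus cuniculus) (on this read-out lower numbers stand for stronger inhibition and higher numbers for weaker inhibition), compound 1 gives 25 nM. Compound 2 gives 27 nM, and compound 3 gives 37 nM. All three values sit within the usual scatter of one another: a 1.1-fold higher number from compound 1 to compound 2 (0.03 log units; within the scatter), a 1.5-fold higher number from compound 1 to compound 3 (0.17 log units; within the scatter), and a 1.4-fold higher number from compound 2 to compound 3 (0.14 log units; within the scatter). Compound 3 thus stands apart from neither compound 1 nor compound 2 beyond what repeated measurement would show.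

Compound 4, `Cc1cc(Oc2ccccc2)c(S(C)(=O)=O)cc1C(=O)N=C(N)N`, is not yet measured. It differs from compound 3 in one place: phenyl in place of cyclohexyl on an oxygen on an aromatic ring. For the measured compounds named here, the step that bears most directly on this change is the one from compound 2 to compound 3, where the group on the oxygen on the aromatic ring was altered and the number stayed within the scatter. The steps from compound 1 to compound 2 and to compound 3, which exchanged the chloro for cyclopentyloxy or cyclohexyloxy, likewise stayed within the scatter. No change at this position has so far moved this assay beyond the scatter, so compound 4 is expected to show a 1.1-fold lower number from compound 3 to compound 4 (0.02 log units; within the scatter), no step beyond the scatter in either direction. Compound 4 is therefore estimated at 35 nM, in a range from 15 nM to 90 nM.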

Compound 4, half-maximal inhibitory concentration: 10 nM
Beside the measured number, compound 4's estimate is 3.5-fold (0.54 log units) above it, outside the stated range (below it).
By their numbers in this assay, from the lowest: compound 4; then compounds 1, 2 and 3 (each within the scatter of the next).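

With phenyl in place of cyclohexyl, this assay shows a 3.7-fold lower number from compound 3 to compound 4 (0.57 log units; beyond the scatter) and so, for the first time among these compounds, a change of the group on the oxygen on the aromatic ring moves the number beyond the scatter, although the leaving and entering groups have the same count of heavy atoms. The other two comparisons point the same way, with phenyl in place of cyclopentyl giving a 2.7-fold lower number from compound 2 to compound 4 (0.43 log units; beyond the scatter) and phenoxy in place of chloro giving a 2.5-fold lower number from compound 1 to compound 4 (0.40 log units; beyond the scatter) and, although all three steps are modest, this position proves able to separate compounds where chloro, cyclopentyloxy and cyclohexyloxy had not. No measurement shown here accounts for the difference between the phenyl and the two saturated rings.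

From the compounds shown here alone, whether a benzyl group on the oxygen, or a phenyl ring carrying a fluoro or methoxy group, would keep or extend this step remains open. Going by these compounds, it is also open whether the step survives if an amine nitrogen takes the place of the oxygen on the aromatic ring.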